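A few compounds are considered here, and "the series" means these few. Any claim that something is new, unique, unknown or untested is made for them only; others in the source may bear on it.

Measured in a functional assay on A549 cells (Homo sapiens) for cytotoxicity, read by MTT assay, with a stated time of 48 h; a higher number here means a weaker inhibitor, a lower number a stronger inhibitor:
Compound 1 `COC(=O)c1ccc2[nH]cc(C3(c4c[nH]c5ccc(C(=O)OC)cc45)C(=O)Nc4ccccc43)c2c1`: 750 nM
Compound 2 `O=C1Nc2ccccc2C1(c1c[nH]c2ccc(Cl)cc12)c1c[nH]c2ccc(Cl)cc12`: > 100000 nM
Compound 3 `N#Cc1ccc2[nH]cc(C3(c4c[nH]c5ccc(C#N)cc45)C(=O)Nc4ccccc43)c2c1`: 970 nM

Compound 1 holds one of the two actual numbers in this set. The other belongs to compound 3, and the two lie within the usual scatter of each other, so they cannot be ranked. Compound 2 gives > 100000 nM, which is a limit of the assay and not a number.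

Compound 4 `COC(=O)c1ccc2[nH]cc(C3(c4c[nH]c5ccc(C(=O)OC)cc45)C(=O)Nc4ccc(Cl)cc43)c2c1` keeps the core of compound 1 but has chloro in place of hydrogen on an aromatic carbon, (chloro in place of hydrogen on an aromatic carbon). The carbon belongs to a six-membered aromatic ring of carbon only. Within the data shown here, no two measured compounds differ in just one place, so no measured step shows what this swap does in this assay. Starting from compound 1 at 750 nM, the expectation is no change beyond the scatter, with a wide margin in either direction. The estimated change is a 1.1-fold higher number from compound 1 to compound 4 (0.03 log units; within the scatter). For compound 4 the estimate is 800 nM, with an expected range of 250 nM to 3000 nM.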

Compound 4, half-maximal inhibitory concentration: 71500 nM
Compound 4: the middle estimate sits 89-fold (1.95 log units) below what was measured; measured number outside the range, above it.
By their numbers in this assay, from the lowest: compounds 1 and 3 (each within the scatter of the next); then compound 4. At a limit, above all of these: compound 2.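

Among these compounds, this is the first single change in the set that can be read: in this assay, chloro in place of hydrogen on an aromatic carbon gives a 95-fold higher number from compound 1 to compound 4 (1.98 log units; beyond the scatter). The position, on a six-membered aromatic ring of carbon only, is therefore far from indifferent to this swap, and one chlorine atom is enough to make compound 4 a much weaker inhibitor than compound 1. The assay also has an upper limit, so a loss of this kind can only be read up to that point: the limit of > 100000 nM in this assay, at which 1 of the 4 values shown sits.

The compounds shown leave open whether this loss belongs to chloro itself or would also follow with fluoro, methyl, methoxy or an amine at this position. They also leave open whether the same swap would act alike on the core of compound 3.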